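The compounds below may be only part of what the source reports. "The series", "measured", "known", "first", "only" and "open" are said of these compounds alone.

Of the compounds shown here, three that share one core have been tested in a functional assay on HeLa cells (Homo sapiens) for cytotoxicity, read by sulforhodamine B assay, with a stated time of 48 h; a lower number here means a stronger inhibitor, a higher number a weaker inhibitor. Compound 1, `CC(=O)OC[C@H]1O[C@@H](n2cc(Cn3cc(C(C)=O)c4ccccc43)nn2)[C@H](OC(C)=O)[C@@H](OC(C)=O)[C@@H]1OC(C)=O`, returns only a limit of the assay: in this assay compound 1 gives > 200000 nM. Compound 2, `COc1ccc2c(c1)c(/C=C1/C(=O)Nc3ccc(F)cc31)cn2Cc1cn([C@@H]2O[C@H](COC(C)=O)[C@@H](OC(C)=O)[C@H](OC(C)=O)[C@H]2OC(C)=O)nn1`, likewise returns a limit of the assay, with this assay giving for compound 2 > 200000 nM. Among the measured compounds shown here, compound 3, `CC(=O)OC[C@H]1O[C@@H](n2cc(CN3C(=O)/C(=C\c4ccccc4)c4ccccc43)nn2)[C@H](OC(C)=O)[C@@H](OC(C)=O)[C@@H]1OC(C)=O`, is the one compound with a number: in this assay compound 3 gives 33300 nM. Compound 3 therefore stands alone among the values shown, since (the limit of > 200000 nM in this assay, at which 2 of the 3 values shown sit).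

Compound 4, `CC(=O)OC[C@H]1O[C@@H](n2cc(CN3C(=O)/C(=C\c4ccc5ccccc5c4)c4ccccc43)nn2)[C@H](OC(C)=O)[C@@H](OC(C)=O)[C@@H]1OC(C)=O`, has not yet been measured. It differs from compound 3 in a single place: naphthalen-2-yl in place of phenyl on a double-bonded chain carbon bound to a double-bonded ring carbon. For the measured compounds named here, no measured pair in this set isolates such a change, so there is no measured step to lean on, and the expectation rests on compound 3 alone. The added ring is expected to shift the result only modestly, in the direction of a stronger inhibitor, and the expected step is a 1.7-fold lower number from compound 3 to compound 4 (0.22 log units; within the scatter), which sits close to the usual scatter of repeated measurements. Compound 4 is accordingly estimated at 20000 nM, with a range from 5000 nM to 100000 nM.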

Compound 4, half-maximal inhibitory concentration: > 100000 nM
Compound 4 gave a limit, no number; the forecaster's own chance of this, stated with the estimate: 15%; middle value at least 5.0-fold (0.69 log units) away from the limit.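

Replacing phenyl with naphthalen-2-yl on a double-bonded chain carbon bound to a double-bonded ring carbon gives an at least 3.0-fold higher number from compound 3 to compound 4 (0.47 log units; beyond the scatter) in this assay, so this position does respond to what is attached there, and this change weakens the compound rather than strengthening it. The step is a minimum and not a measured size, and compound 4 now also belongs among the compounds that return only a limit of the assay: the limit of > 100000 nM in this assay, at which 1 of the 4 values shown sits. Compound 3, at 33300 nM, therefore remains the only compound shown with an actual number, and phenyl is the only group at this position known to give one.

From the compounds shown here alone, with only phenyl and naphthalen-2-yl compared at this place, it remains open whether a smaller group such as methyl, or a phenyl ring carrying an amine or a carboxylic acid, would give a lower number than compound 3. The two compounds also cannot show whether the loss belongs to naphthalen-2-yl alone or would extend to other groups of similar size, such as naphthalen-1-yl.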